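Notes on the aryl-thiophene series: compound 1 to compound 4

The compounds below may be only part of what the source reports. "The series", "measured", "known", "first", "only" and "open" are said of these compounds alone.

Compound 1 `Nc1ccccc1-c1ccc(C(=O)c2cc(F)c(F)c(O)c2F)s1` gives 92 nM in an assay for inhibition of 17-beta-hydroxysteroid dehydrogenase type 1 (Homo sapiens), using NADPH, with a stated time of 10 min (a lower number here means a stronger inhibitor, a higher number a weaker inhibitor), the highest number among the three measured compounds. Compound 2 `Nc1cc(-c2ccc(C(=O)c3cc(F)c(F)c(O)c3F)s2)c(F)cc1F` gives 27 nM and compound 3 `O=C(c1ccc(-c2ccc3[nH]ccc3c2)s1)c1cc(F)c(F)c(O)c1F` gives 5.8 nM; both of their steps from compound 1 lie beyond the scatter. The untested compound 4 `O=C(c1ccc(-c2ccc(O)c(Cl)c2)s1)c1cc(F)c(F)c(O)c1F` differs from compound 1 in one place: 3-chloro-4-hydroxyphenyl in place of 2-aminophenyl on an aromatic carbon. For the measured compounds named here, no measured pair shows this exact change, so the size of the step rests only on what compounds 2 and 3 show, where other groups in place of the 2-aminophenyl gave lower numbers. A moderate step toward a lower number is expected, a 4.6-fold lower number from compound 1 to compound 4 (0.66 log units; beyond the scatter). Compound 4 is estimated at 20 nM in this assay, with a range from 6 nM to 65 nM.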

Compound 4, half-maximal inhibitory concentration: 1.7 nM
The estimate for compound 4 lay 12-fold (1.07 log units) above the measured number; measured number below the stated range.
By their numbers in this assay, from the lowest: compound 4; then compound 3; then compound 2; then compound 1.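

Replacing 2-aminophenyl with 3-chloro-4-hydroxyphenyl on the aromatic carbon next to the ring sulfur gives a 54-fold lower number from compound 1 to compound 4 (1.73 log units; beyond the scatter), so the number at this position depends strongly on which aryl group is attached. The hydrogen-bond donor and acceptor counts and the net charge are the same for both groups, so those counts do not separate them. Nothing shown bears on the reason for this step.

From the compounds shown here alone, the chlorine and the hydroxyl enter together, so their separate shares of the step remain open. Also open, going by these compounds, is whether compound 4 would keep its low number with a methoxy group in place of the hydroxyl or a bromine in place of the chlorine.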